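A few compounds are considered here, and "the series" means these few. Any claim that something is new, unique, unknown or untested is made for them only; others in the source may bear on it.

The measured compounds:

compound 1, `COc1cc2c(Oc3ccc(NC(=O)c4nn(-c5ccccc5)c(=O)c5ccccc45)cc3F)ccnc2cc1OCCCN1CCCC1`, which in a functional assay on MDA-MB-231 cells (Homo sapiens) for cytotoxicity, read by MTT assay, with a stated time of 72 h (a higher number here means a weaker inhibitor, a lower number a stronger inhibitor), gives 1130 nM

compound 2, `COc1cc2c(Oc3ccc(NC(=O)c4nn(-c5ccc(Br)cc5)c(=O)c5ccccc45)cc3F)ccnc2cc1OCCCN1CCCC1`, which in this assay gives 1160 nM

compound 3, `COc1cc2c(Oc3ccc(NC(=O)c4nn(-c5ccccc5)c(=O)c5ccccc45)cc3F)ccnc2cc1OCCCN1CCCCC1`, which in this assay gives 1880 nM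

Compound 3 holds the highest of the three numbers in this assay, yet none of its gaps to the others reaches beyond the usual scatter. The step of a 1.7-fold higher number from compound 1 to compound 3 (0.22 log units; within the scatter) is within the scatter, and the number of compound 2 differs from that of compound 3 by even less, so no order among the three can be claimed.

Compound 4, `COc1cc2c(Oc3ccc(NC(=O)c4nn(-c5ccc(Br)cc5)c(=O)c5ccccc45)cc3F)ccnc2cc1OCCCN1CCCCC1`, differs from compound 3 in one place: bromo in place of hydrogen on an aromatic carbon. The same change has been measured once in this series, between compound 1 and compound 2, where the step was a 1.0-fold higher number from compound 1 to compound 2 (0.01 log units; within the scatter), which is no change at all in practice. Nothing else among the measured compounds bears on this change. On that single precedent, compound 4 is expected to stay close to compound 3, with an expected step of a 1.0-fold higher number from compound 3 to compound 4 (0.00 log units; within the scatter) in this assay, that is, no step beyond the scatter in either direction. For compound 4 the estimate in this assay is therefore 1900 nM, with a range from 1000 nM to 3600 nM.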

Compound 4, half-maximal inhibitory concentration: 1130 nM
The estimate for compound 4 lay 1.7-fold (0.23 log units) above the measured number; the range from low to high includes it.
By their numbers in this assay, from the lowest: compounds 1, 4, 2 and 3 (each within the scatter of the next).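

Bromo in place of hydrogen, the change from phenyl to 4-bromophenyl, has now been read with piperidin-1-yl at the chain end as well as with pyrrolidin-1-yl, and in this assay the new reading, a 1.7-fold lower number from compound 3 to compound 4 (0.22 log units; within the scatter), also stays within the scatter, so neither reading of this change at this position shows a real step: the same change on two cores in this assay, a 1.0-fold higher number (0.01 log units; within the scatter) from compound 1 to compound 2 and a 1.7-fold lower number (0.22 log units; within the scatter) from compound 3 to compound 4, 1.7-fold (0.23 log units) apart, within the scatter of two such steps. The change from pyrrolidin-1-yl to piperidin-1-yl, earlier read only with the unsubstituted phenyl, now has a reading with 4-bromophenyl, a 1.0-fold lower number from compound 2 to compound 4 (0.01 log units; within the scatter), and this too gives no step beyond the scatter: the same change on two cores in this assay, a 1.7-fold higher number (0.22 log units; within the scatter) from compound 1 to compound 3 and a 1.0-fold lower number (0.01 log units; within the scatter) from compound 2 to compound 4, 1.7-fold (0.23 log units) apart, within the scatter of two such steps. Among the compounds shown here, the four compounds thus complete a square of two changes in which no step leaves the scatter, and no dependence of one change on the other can be claimed.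

The compounds shown speak only of hydrogen and bromo on this aromatic carbon and of two ring amines at the chain end. On these data alone, whether a methoxy group or a nitrile at that carbon, morpholin-4-yl at the chain end, or a longer chain would move the number beyond the scatter remains open.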